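The source may report more compounds than this note shows. Statements on the series, on what has been measured and on what is new or still open speak of the compounds shown alone.

Compound 1 `CCc1ccc(NS(=O)(=O)c2cccc(CCCCCCNC(=O)/C=C/c3cccnc3)c2)cc1`: 40.1 nM
Compound 2 `O=C(/C=C/c1cccnc1)NCCCCCCc1cccc(S(=O)(=O)Nc2ccc(F)c(Cl)c2)c1`: 150 nM

In a functional assay on DU-145 cells (Homo sapiens) for inhibition, read by CCK-8 assay, with a stated time of 72 h (on this read-out higher numbers stand for weaker inhibition and lower numbers for stronger inhibition), compound 2 gives the higher of the two numbers, 150 nM. Compound 3 `O=C(/C=C/c1cccnc1)NCCCCCCc1cccc(S(=O)(=O)Nc2ccc(C(F)(F)F)cc2)c1` differs from it in one place, with 4-(trifluoromethyl)phenyl in place of 3-chloro-4-fluorophenyl on a sulfonamide nitrogen. Going by the values given here, only one measured step changes this same group, and it is modest: a 3.7-fold higher number from compound 1 to compound 2 (0.57 log units; beyond the scatter). Among the compounds with values here, no measured compound carries the entering group, so a step beyond the scatter is not expected, though a slightly lower number seems likelier. The expected change is a 1.7-fold lower number from compound 2 to compound 3 (0.22 log units; within the scatter). Compound 3 is estimated at 90 nM, within a range of 32 nM to 250 nM.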

Compound 3, half-maximal inhibitory concentration: 1410 nM
Compound 3: middle estimate off by 16-fold (1.19 log units), on the low side; measured number outside the range, above it.
By their numbers in this assay, from the lowest: compound 1; then compound 2; then compound 3.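

In this assay the group on the sulfonamide nitrogen proves able to shift the number much further than the earlier pair showed: 4-(trifluoromethyl)phenyl in place of 3-chloro-4-fluorophenyl gives a 9.4-fold higher number from compound 2 to compound 3 (0.97 log units; beyond the scatter), and trifluoromethyl in place of ethyl on an aromatic carbon gives a 35-fold higher number from compound 1 to compound 3 (1.55 log units; beyond the scatter). Among these three groups, 4-ethylphenyl thus gives the lowest number and 4-(trifluoromethyl)phenyl the highest. Nothing measured here explains this order.

From the compounds shown here alone, whether a 4-methoxyphenyl or 4-aminophenyl group on that nitrogen would stand nearer compound 1 or compound 3 remains open. So does whether this order would hold with a shorter chain.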